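The source may report more compounds than this note shows. Statements on the series, on what has been measured and on what is new or still open speak of the compounds shown alone.

Working notes on the series. Within the data shown here, in an ADME assay on cells (Epithelial cell, Homo sapiens) for antiproliferative activity, read by MTT assay, with a stated time of 48 h (a higher number here means a weaker inhibitor, a lower number a stronger inhibitor), compound 1 (`COC(=O)/C(=C/c1ccccc1)CN1C(=O)[C@@H](OC)[C@H]1c1ccc(F)cc1`) gives 27900 nM, the only number available so far, so it can be placed against no other measured value. Among the measured compounds shown here, compound 2 (`COC(=O)/C(=C/c1ccccc1)CN1C(=O)[C@@H](OC)[C@H]1c1cccc(Cl)c1`) is recorded as "not toxic" (no number reported), without a number, and no measured step exists to serve as a guide.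

Compound 3 (`CCOC(=O)/C(=C/c1ccccc1)CN1C(=O)[C@@H](OC)[C@H]1c1ccc(F)cc1`) keeps the core of compound 1 and differs in one place: methyl in place of hydrogen on a saturated chain carbon bound to an oxygen next to a carbonyl group. This is methyl in place of hydrogen on a saturated chain carbon bound to an oxygen next to a carbonyl group, which reads as methoxycarbonyl to ethoxycarbonyl.

For the measured compounds named here, with no step to calibrate against, the expectation in this assay is no change beyond the scatter and no firm direction. The estimate rests on compound 1 at 27900 nM as its anchor, and the range is kept wide. A result without a number, as for compound 2 at "not toxic" (no number reported), also remains possible. The expected change is a 1.1-fold lower number from compound 1 to compound 3 (0.03 log units; within the scatter), which would lie within the usual scatter. For compound 3 the estimated value is 26000 nM, with an expected range of 11000 nM to 60000 nM.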

Compound 3, half-maximal inhibitory concentration: "not toxic" (no number reported)
Compound 3: no number reported; no gap can be computed for the estimate.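

Among these compounds, compound 3 carries no number in this assay, and no step from compound 1 to compound 3 can be read. Nothing shown bears on this result. The compounds shown leave open whether going from methoxycarbonyl to ethoxycarbonyl moves the value of compound 1, 27900 nM, in either direction.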